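The source may hold more compounds than are shown below. What is called first, only, known or untested is meant among the compounds shown, and "the series" means these compounds.

Of the compounds shown here, three sharing one core have been measured so far in a physicochemical assay for solubility, with a stated time of 3 days, at pH 2 (a higher number here means a more soluble compound, a lower number a less soluble compound), and only one of them gives an exact reading. Compound 1 `NC(=O)c1ccc2[nH]c(-c3ccc(OCC4CCNCC4)cc3)nc2c1` gives > 400000 nM as a limit of the assay and not a number. Compound 2 `NC(=O)c1ccc2[nH]c(-c3ccc(OCCC4CCCCN4Cc4ccccc4)cc3)nc2c1` gives > 400000 nM as a limit too. Compound 2 therefore stands at the limit of > 400000 nM in this assay, at which 2 of the 3 values shown sit, and has no exact value of its own. Within the data shown here, compound 3 `NC(=O)c1ccc2[nH]c(-c3ccc(OCCC4CCN(Cc5ccc(Cl)cc5)CC4)cc3)nc2c1` gives 179000 nM as the one true number in the set.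

Compound 4 `NC(=O)c1ccc2[nH]c(-c3ccc(OCCC4CCCCN4C(=O)c4ccccc4)cc3)nc2c1` is compound 2 with benzoyl in place of benzyl on an amine nitrogen in a ring, next to the ring atom that bears a large group (benzoyl in place of benzyl on an amine nitrogen in a ring). Among the measured compounds shown here, no step between measured compounds speaks to this change, and compound 2 offers only a limit as a starting point. The single number at hand, compound 3 at 179000 nM in this assay, shows that an exact reading can occur among these compounds, so a fall beyond the scatter is expected rather than no change. That expected fall is estimated as an at least 2.6-fold lower number from compound 2 to compound 4 (0.42 log units; beyond the scatter) and remains uncertain. Compound 4 is estimated at 150000 nM in this assay, with an expected range from 40000 nM to 400000 nM as the likely span.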

Compound 4, solubility: 28000 nM
The estimate for compound 4 lay 5.4-fold (0.73 log units) above the measured number; the whole stated range lies above it.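

Benzoyl in place of benzyl on an amine nitrogen in a ring gives, in this assay, an at least 14-fold lower number from compound 2 to compound 4 (1.15 log units; beyond the scatter). Among these compounds, this is the first step between compounds that differ in one place, and it shows that the group on this nitrogen can move the reading well beyond the scatter, even though the two groups differ on paper only by a carbonyl and the hydrogen-bond acceptor counted with it. The step gives only a minimum for the size of the change, and its full size cannot be stated, because compound 2 carries a limit of the assay and not a number: the limit of > 400000 nM in this assay, at which 2 of the 4 values shown sit.

The compounds shown leave open whether the fall belongs to the benzoyl group as a whole or to the carbonyl alone, which an acetyl group, a methanesulfonyl group or a plain methyl group on the same nitrogen would help to separate. They also leave open whether the same exchange would give a step of similar size on the other ring nitrogen, the one that carries 4-chlorobenzyl in compound 3.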